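Replacing cyano with 1,3-oxazol-2-yl on a saturated ring carbon

A few compounds are considered here, and "the series" means these few. Any claim that something is new, unique, unknown or untested is made for them only; others in the source may bear on it.

In an ADME assay on the whole organism (Mus musculus, strain ICR) for pharmacokinetics, at a dose of 50 mg/kg by the oral route (a higher number here means more compound in the circulation at the dose given, a lower number less compound in the circulation), compound 1 `O=C1CC(Oc2ncccn2)CN1c1cnn2c1CN(C(=O)Nc1cc(F)c(F)c(F)c1)C(C1CC1)C2` gives 4020 ng.h/mL while compound 2 `N#CC1CC(=O)N(c2cnn3c2CN(C(=O)Nc2cc(F)c(F)c(F)c2)C(C2CC2)C3)C1` gives 10600 ng.h/mL and so stands higher of the two. Within the data shown here, the only measured step is a 2.6-fold higher number from compound 1 to compound 2 (0.42 log units; beyond the scatter) and it lies beyond the scatter, though it is modest. It came with cyano in place of (pyrimidin-2-yl)oxy on a saturated ring carbon.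

Compound 3 `O=C1CC(c2ncco2)CN1c1cnn2c1CN(C(=O)Nc1cc(F)c(F)c(F)c1)C(C1CC1)C2` keeps the shared core and alters that same carbon, with 1,3-oxazol-2-yl in place of cyano on a saturated ring carbon as the counted difference. In words, 1,3-oxazol-2-yl takes the place of cyano. Among the measured compounds shown here, this group has not been measured before, so the single step offers only a loose guide. Compound 1 also carries an aromatic ring in its group on that carbon and gives 4020 ng.h/mL as its number, so a modest fall in this assay is expected for the new ring. The estimated change is a 2.1-fold lower number from compound 2 to compound 3 (0.33 log units; beyond the scatter) and it could prove smaller or larger. Compound 3 is estimated at 5000 ng.h/mL with an expected range from 2000 ng.h/mL to 12500 ng.h/mL in this measurement.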

Compound 3, area under the concentration-time curve: 12200 ng.h/mL
Beside the measured number, compound 3's estimate is 2.4-fold (0.39 log units) below it, within the range that was stated.
By their numbers in this assay, from the lowest: compound 1; then compounds 2 and 3 (each within the scatter of the next).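

In this assay the 1,3-oxazol-2-yl group takes the place of the much smaller cyano with a 1.2-fold higher number from compound 2 to compound 3 (0.06 log units; within the scatter), so this saturated ring carbon accepts a five-membered aromatic ring without any clear difference in the read-out. Set against the (pyrimidin-2-yl)oxy group of compound 1, the same ring gives a 3.0-fold higher number from compound 1 to compound 3 (0.48 log units; beyond the scatter), which shows that an aromatic ring in the group on this carbon does not by itself go with the lower number of compound 1; among these three compounds, only compound 1 stands apart, with compounds 2 and 3 within the scatter of each other. No measurement is at hand to explain why the groups on this carbon give these numbers.

The compounds shown leave open whether the oxygen link or the pyrimidine ring sets compound 1 apart, a question that pyrimidin-2-yl attached directly to the carbon would address. They also leave open how far this tolerance extends, as an amine, a carboxylic acid or a longer chain on the same carbon could give a quite different number in this assay.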